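This account rests on a few compounds, and the source may have more. Where it says the series, first, only, none or still open, it means among the compounds named here.

In an ADME assay on CHO cells (Cricetulus griseus) for cytotoxicity, read by MTT assay, with a stated time of 68 h (on this read-out higher numbers stand for weaker inhibition and lower numbers for stronger inhibition), the measured compounds read:

Compound 1 `O=C(/C=C/c1cccc(OCc2ccccc2)c1)c1ccc([N+](=O)[O-])cc1` gives 82400 nM
Compound 2 `O=C(/C=C/c1cccc(OCc2ccccc2)c1)c1ccc(Cl)cc1Cl` gives 27500 nM
Compound 3 `O=C(/C=C/c1cccc(OCc2ccccc2)c1)c1ccc(Cl)cc1` gives 43600 nM

Compound 1 carries the highest of these numbers, a lead that clears the scatter only in a 3.0-fold lower number from compound 1 to compound 2 (0.48 log units; beyond the scatter) and not in a 1.9-fold lower number from compound 1 to compound 3 (0.28 log units; within the scatter). Compound 4 `O=C(/C=C/c1cccc(OCc2ccccc2)c1)c1ccccc1Br` has 2-bromophenyl in place of 4-nitrophenyl on a carbonyl carbon. Among the compounds with values here, no bromo compound has been measured, so the two steps above are the nearest guides, and a 1.6-fold higher number from compound 2 to compound 3 (0.20 log units; within the scatter) stays small. A modest fall in the number is therefore expected, with the expected step being a 2.2-fold lower number from compound 1 to compound 4 (0.34 log units; beyond the scatter). For compound 4 the estimate is 38000 nM, with an expected range from 17000 nM to 80000 nM.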

Compound 4, half-maximal inhibitory concentration: 9100 nM
The estimate for compound 4 lay 4.2-fold (0.62 log units) above the measured number; the measured number lies below the stated range.
By their numbers in this assay, from the lowest: compound 4; then compounds 2, 3 and 1 (each within the scatter of the next, the first and the last beyond it).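

Against all the earlier aryl groups, the 2-bromophenyl on this carbonyl carbon gives the lowest number in this assay: there is a 9.1-fold lower number from compound 1 to compound 4 (0.96 log units; beyond the scatter) and a 4.8-fold lower number from compound 3 to compound 4 (0.68 log units; beyond the scatter) and a 3.0-fold lower number from compound 2 to compound 4 (0.48 log units; beyond the scatter). Within the data shown here, this position can therefore move the number further than the earlier compounds showed, and compound 4 stands clear of all three. No measurement given here accounts for this shift.

The compounds shown do not separate the bromine from its place on the ring. On these data alone, how an amine or a carboxylic acid on that ring would read also remains open.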